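This account rests on a few compounds, and the source may have more. Where it says the series, first, only, none or still open, it means among the compounds named here.

Compound 1 `CC(c1ccc(F)cc1)N(Cc1cccc(C(=O)O)c1)C(=O)c1ccc2c(c1)CCO2`: in an assay on CHO T-rex cells for antagonist activity at transient receptor potential cation channel subfamily M member 8 (Homo sapiens), read by calcium flux, with a stated time of 20 min (on this read-out lower numbers stand for stronger inhibition and higher numbers for weaker inhibition), compound 1 gives 3620 nM.
Compound 2 `C[C@H](c1ccc(F)cc1)N(Cc1cccc(CC(=O)O)c1)C(=O)c1cnc2ccccc2c1`: in this assay compound 2 reaches only a limit, > 3240 nM.
Compound 3 `O=C(O)c1cccc(CN(Cc2ccc(F)cc2)C(=O)c2cnc3ccccc3c2)c1`: in this assay compound 3 reaches only a limit, > 9350 nM.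

Compound 3 therefore stands at the weaker end of what is known here, with no number of its own, only the limit described by the limit of > 9350 nM in this assay, at which 1 of the 3 values shown sits; compound 2 likewise sits at a limit, (the limit of > 3240 nM in this assay, at which 1 of the 3 values shown sits). Compound 4 `O=C(O)c1cccc(CN(C(=O)c2cnc3ccccc3c2)[C@H](CO)c2ccccc2)c1` differs from compound 3 in one place: 2-hydroxy-1-phenylethyl in place of 4-fluorobenzyl on an amide-type nitrogen. Within the data shown here, no measured pair shows what such a change does, so the expected step from compound 3 to compound 4 is estimated as small, an at least 1.5-fold lower number from compound 3 to compound 4 (0.19 log units; that floor lies within the scatter), possibly within the scatter. Compound 4 is expected to give about 6000 nM, between 1500 nM and 25000 nM.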

Compound 4, half-maximal inhibitory concentration: > 6860 nM
Compound 4 gave a limit, no number; the forecaster's own chance of this, stated with the estimate: 50%; at least 1.1-fold (0.05 log units) between middle value and limit.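

Compound 3 and compound 4 each give only a limit in this assay, and the step between them cannot be read. The compounds shown leave open what 2-hydroxy-1-phenylethyl in place of 4-fluorobenzyl does to inhibition.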